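Compound 4: bromo in place of chloro

This account rests on a few compounds, and the source may have more. Where it says the series, first, only, none or still open, it means among the compounds named here.

Compound 1 `CC1=NN(c2ccc(Br)cc2)C(=O)C12C=CC(=O)C=C2c1ccccc1`: in a functional assay on HCT-116 cells (Homo sapiens) for antiproliferative activity, read by CCK-8 assay, with a stated time of 72 h (on this read-out lower numbers stand for stronger inhibition and higher numbers for weaker inhibition), compound 1 gives > 100000 nM, which is a limit of the assay.
Compound 2 `CC1=NN(c2ccc(Cl)cc2)C(=O)C12C=CC(=O)C=C2c1ccccc1`: in this assay compound 2 gives > 100000 nM, again a limit.
Compound 3 `CC1=NN(c2ccc(Cl)cc2)C(=O)C12C=CC(=O)C=C2c1ccc(C)cc1`: in this assay compound 3 gives 10300 nM.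

For the measured compounds named here, compound 3 therefore holds the only measured number in the set; the other two values sit at the limit of > 100000 nM in this assay, at which 2 of the 3 values shown sit. The step of an at least 9.7-fold lower number from compound 2 to compound 3 (0.98 log units; beyond the scatter) came with methyl in place of hydrogen. Compound 4 `CC1=NN(c2ccc(Br)cc2)C(=O)C12C=CC(=O)C=C2c1ccc(C)cc1` differs from compound 3 by bromo in place of chloro on an aromatic carbon. Going by the values given here, the one measured step on this exchange, a step that the two limits leave unreadable from compound 1 to compound 2, runs the other way and lies between two limits, so its size cannot be read. No step beyond the scatter bears on it. Compound 4 is thus expected to give about 10300 nM, between 3400 nM and 31000 nM. The step this estimate means, no change at the digits printed from compound 3 to compound 4 (within the scatter), is expected to stay within the scatter.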

Compound 4, half-maximal inhibitory concentration: 10600 nM
Compound 4: the middle estimate sits 1.0-fold (0.01 log units) below what was measured; low and high end bracket the measured number.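

For the compounds shown here, with the methyl group present, the 4-chlorophenyl to 4-bromophenyl exchange can be read in this assay for the first time, as a 1.0-fold higher number from compound 3 to compound 4 (0.01 log units; within the scatter). The methyl in place of hydrogen on an aromatic carbon now also comes with bromo, as an at least 9.4-fold lower number from compound 1 to compound 4 (0.97 log units; beyond the scatter). The change thus appears with both halogens: the limit of > 100000 nM in this assay, at which 2 of the 4 values shown sit.

Without the methyl group, the halogen exchange cannot be read, as compound 1 and compound 2 are both limits of the assay. The compounds shown leave open how an amine, a carboxylic acid or a longer chain would read in place of that methyl group.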